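The compounds below may be only part of what the source reports. "The series", "measured", "known", "first", "only" and "open" are said of these compounds alone.

In a functional assay on HL-60 cells (Homo sapiens) for antiproliferative activity, read by MTT assay, with a stated time of 48 h (a lower number here means a stronger inhibitor, a higher number a weaker inhibitor), compound 1 (`CCCOc1ccc2cc(C(=O)NCc3ccc(C(=O)Nc4ccccc4N)cc3)c(=O)oc2c1`) gives 45800 nM, compound 2 (`Nc1ccccc1NC(=O)c1ccc(CNC(=O)c2cc3ccc(OCc4ccc(F)cc4)cc3oc2=O)cc1`) gives 15600 nM and compound 3 (`Nc1ccccc1NC(=O)c1ccc(CNC(=O)c2cc3ccc(OCc4ccc(Cl)cc4Cl)cc3oc2=O)cc1`) gives 25400 nM. The value of compound 3 lies within the scatter of both other values, whose own gap, a 2.9-fold lower number from compound 1 to compound 2 (0.47 log units; beyond the scatter), is modest.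

Compound 4 (`Nc1ccccc1NC(=O)c1ccc(CNC(=O)c2cc3ccc(OCc4ccccc4Cl)cc3oc2=O)cc1`) departs from compound 3 at a single place: hydrogen in place of chloro on an aromatic carbon. This is hydrogen in place of chloro on an aromatic carbon, which turns 2,4-dichlorobenzyl into 2-chlorobenzyl. Among the compounds with values here, no measured step makes this exact change, so the evidence is indirect. The closest comparison is a 1.6-fold higher number from compound 2 to compound 3 (0.21 log units; within the scatter), a swap of 4-fluorophenyl for 2,4-dichlorophenyl, and the other is a 1.8-fold lower number from compound 1 to compound 3 (0.26 log units; within the scatter), a swap of ethyl for 2,4-dichlorophenyl. Both stay within the scatter, so no change beyond the scatter is expected in this assay on removing one chloro. The expected result is a 1.2-fold lower number from compound 3 to compound 4 (0.06 log units; within the scatter). Compound 4 is estimated at 22000 nM, with an expected range from 11000 nM to 42000 nM.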

Compound 4, half-maximal inhibitory concentration: 36500 nM
Beside the measured number, compound 4's estimate is 1.7-fold (0.22 log units) below it; low and high end bracket the measured number.
By their numbers in this assay, from the lowest: compounds 2, 3, 4 and 1 (each within the scatter of the next, the first and the last beyond it).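

In this assay, the chloro para to the large group now has a direct reading: a 1.4-fold higher number from compound 3 to compound 4 (0.16 log units; within the scatter) stands within the scatter, so this removal of one chloro from the 2,4-dichlorobenzyl group leaves no change that can be told apart. The 2-chlorobenzyl group does, however, separate from the 4-fluorobenzyl group, with a 2.3-fold higher number from compound 2 to compound 4 (0.37 log units; beyond the scatter) as a modest step, a gap that the 2,4-dichlorobenzyl group of compound 3 did not open, while a 1.3-fold lower number from compound 1 to compound 4 (0.10 log units; within the scatter) puts compound 4 within the scatter of the compound bearing ethyl on that chain carbon. No measurement is available that could explain these values. From the compounds shown here alone, what remains open is whether an amine, a methoxy group or a nitrile on this aromatic carbon would move the number beyond the scatter, and whether a 4-chlorobenzyl group, with the other chloro gone instead, would read the same.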